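The compounds below may be only part of what the source reports. "The series", "measured", "known", "first", "only" and "open" are said of these compounds alone.

Compound 1 `Cc1cccc(OS(=O)(=O)c2ccc(N3CCN(C)C3=O)cc2)c1`: 2300 nM
Compound 2 `CN1CCN(c2ccc(S(=O)(=O)Oc3cccc(Br)c3)cc2)C1=O`: 1300 nM
Compound 3 `CN1CCN(c2ccc(S(=O)(=O)Oc3ccc(Cl)cc3)cc2)C1=O`: 43000 nM

In a functional assay on M21 cells (Homo sapiens) for antiproliferative activity, read by sulforhodamine B assay, with a stated time of 48 h (on this read-out higher numbers stand for weaker inhibition and lower numbers for stronger inhibition), compound 3 stands at the highest number of the three, beyond the scatter from both others: a 19-fold higher number from compound 1 to compound 3 (1.27 log units; beyond the scatter) and a 33-fold higher number from compound 2 to compound 3 (1.52 log units; beyond the scatter). Compound 4 `CCCN1CCN(c2ccc(S(=O)(=O)Oc3ccc(Cl)cc3)cc2)C1=O` differs from compound 3 in one place: ethyl in place of hydrogen on a saturated chain carbon bound to an amide-type nitrogen in a ring. For the measured compounds named here, all three measured steps change the phenyl group bound to oxygen; none touches the chain on the ring nitrogen, so no measured step bears on this change, and whether the step is large or small is simply unknown. With nothing to build on, no step beyond the scatter is expected, and the expected step is no change at the digits printed from compound 3 to compound 4 (within the scatter). Compound 4 is therefore estimated at 43000 nM, within a range from 12000 nM to 150000 nM.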

Compound 4, half-maximal inhibitory concentration: 34000 nM
The estimate for compound 4 lay 1.3-fold (0.10 log units) above the measured number; low and high end bracket the measured number.
By their numbers in this assay, from the lowest: compounds 2 and 1 (each within the scatter of the next); then compounds 4 and 3 (each within the scatter of the next).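

Ethyl in place of hydrogen on a saturated chain carbon bound to an amide-type nitrogen in a ring, the same difference as methyl to propyl, gives a 1.3-fold lower number from compound 3 to compound 4 (0.10 log units; within the scatter) in this assay, so with the 4-chlorophenyl group this chain can grow without a step beyond the scatter. Nothing available explains this result.

From the compounds shown here alone, whether a butyl chain, an amine or a carboxylic acid at this place would also leave the number unmoved stays open. So does whether propyl would behave alike with the 3-bromophenyl group of compound 2.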